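The source may hold more compounds than are shown below. What is called first, only, known or untested is meant among the compounds shown, and "the series" means these compounds.

Measured compounds in a functional assay (FL5.12 cells, Mus musculus) with Apoptosis regulator Bcl-2 (Homo sapiens) as the target; a higher number here means that more compound is needed for the effect, a lower number that less compound is needed:
- compound 1 `COc1ccccc1C=C1CCN(c2ccc(C(=O)NS(=O)(=O)c3ccc(N[C@H](CCN(C)C)CSc4ccccc4)c([N+](=O)[O-])c3)cc2)CC1` gives 250 nM
- compound 2 `CN(C)CC[C@H](CSc1ccccc1)Nc1ccc(S(=O)(=O)NC(=O)c2ccc(N3CCC(=Cc4cccnc4)CC3)cc2)cc1[N+](=O)[O-]` gives 5300 nM
- compound 3 `CN(C)CC[C@H](CSc1ccccc1)Nc1ccc(S(=O)(=O)NC(=O)c2ccc(N3CCN(C(=O)Nc4ccccc4)CC3)cc2)cc1[N+](=O)[O-]` gives > 50000 nM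

For compound 3 the value in this assay is a limit of the assay, not a number (the limit of > 50000 nM in this assay, at which 1 of the 3 values shown sits). On the numbers shown, compound 3 therefore stands apart from compound 1 and compound 2 at the weak end of the series, with no number of its own.

Compound 4 `COc1ccccc1CN1CCN(c2ccc(C(=O)NS(=O)(=O)c3ccc(N[C@H](CCN(C)C)CSc4ccccc4)c([N+](=O)[O-])c3)cc2)CC1` is not yet measured. It differs from compound 3 in one place: 2-methoxybenzyl in place of phenylcarbamoyl on an amine nitrogen in a ring. The group that enters carries the same 2-methoxyphenyl unit that compound 1 bears on its double-bonded chain carbon, while compound 3 carries no such unit.

Among the measured steps, only one bears on the aryl unit at this end of the core: a 21-fold higher number from compound 1 to compound 2 (1.33 log units; beyond the scatter). That step shows that exchanging the 2-methoxyphenyl unit for another ring moves the value strongly in this assay. The step from compound 3 to compound 4 goes the other way, installing the 2-methoxyphenyl-bearing group in place of the phenylcarbamoyl group, so a large step toward a lower number is expected, though it starts from a limit rather than a number.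

Compound 4 is expected to give about 600 nM in this assay, within a range of 100 nM to 4000 nM. This estimate means an expected step of an at least 83-fold lower number from compound 3 to compound 4 (1.92 log units; beyond the scatter).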

Compound 4, half-maximal effective concentration: 950 nM
Compound 4: the middle estimate sits 1.6-fold (0.20 log units) below what was measured, within the range that was stated.
By their numbers in this assay, from the lowest: compound 1; then compound 4; then compound 2. At a limit, above all of these: compound 3.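

In this assay, the amine nitrogen in the six-membered non-aromatic ring with 2 nitrogen now tolerates a substituent that gives a measurable value: with 2-methoxybenzyl in place of phenylcarbamoyl, the result is an at least 52-fold lower number from compound 3 to compound 4 (1.72 log units; beyond the scatter). Compound 3 carries a limit, not a number, so this step has only a minimum size: the limit of > 50000 nM in this assay, at which 1 of the 4 values shown sits. The two groups have the same count of heavy atoms, and each has one six-membered aromatic ring of carbon only, yet phenylcarbamoyl has a hydrogen-bond donor and a double bond outside aromatic rings, whereas 2-methoxybenzyl has neither, so a change that leaves these counts the same can still be paired with a large step.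

The compounds shown do not separate the contribution of the methoxy group from that of removing the carbamoyl unit, and a plain benzyl or a longer 2-phenylethyl chain on the same ring nitrogen would bear on that question. On these data alone, it also remains open which of the differences between the two groups accounts for the step, and how far below the limit of compound 3 the true gap lies.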